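The compounds below may be only part of what the source reports. "The series", "measured", "known", "first", "only" and "open" are said of these compounds alone.

Measured compounds: compound 1 `CCCCNc1nc(SCC)nc2ncccc12`, 9200 nM; compound 2 `CCCCCCNc1nc(SC(C)C)nc2ncccc12`, 4500 nM; compound 3 `CCCCNc1nc(SCCCC)nc2ncccc12`, 8400 nM.

For the measured compounds named here, in a functional assay on MDA-MB-231 cells (Homo sapiens) for cytotoxicity, read by neutral red uptake, with a stated time of 72 h (a higher number here means a weaker inhibitor, a lower number a stronger inhibitor), compound 3 sits second highest of the three numbers; its nearest neighbour is compound 1, and the only step within this assay that is measured as a single change is a 1.1-fold lower number from compound 1 to compound 3 (0.04 log units; within the scatter), which falls within the scatter. The furthest number belongs to compound 2, and its gap to compound 3 also stays within the scatter.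

Compound 4 `CCCCCCNc1nc(SCCCC)nc2ncccc12` differs from compound 3 by ethyl in place of hydrogen on a saturated chain carbon, four bonds along the chain from a nitrogen on an aromatic ring, so the butyl on the aromatic-ring nitrogen becomes hexyl while the thioether chain is kept. Going by the values given here, no measured pair isolates this change. Compound 2 carries the same hexyl on that nitrogen together with a different thioether chain, and its number against compound 3 shows only a gap within the scatter. Among the compounds with values here, the one measured single step, that from compound 1 to compound 3, is likewise within the scatter. Taken together these points give no reason to expect a step beyond the scatter for compound 4, and a 1.3-fold lower number from compound 3 to compound 4 (0.11 log units; within the scatter) is therefore the expected step, leaning at most slightly to a lower number. Compound 4 is estimated at 6500 nM, within 3000 nM to 14000 nM.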

Compound 4, half-maximal inhibitory concentration: 1200 nM
Compound 4: middle estimate off by 5.4-fold (0.73 log units), on the high side; measured number outside the range, below it.
By their numbers in this assay, from the lowest: compound 4; then compounds 2, 3 and 1 (each within the scatter of the next, the first and the last beyond it).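

In this assay, for the compounds shown here, butyl to hexyl on the aromatic-ring nitrogen, with butyl kept on the sulfur, gives a 7.0-fold lower number from compound 3 to compound 4 (0.85 log units; beyond the scatter), the first single change to go beyond the scatter. With hexyl held on that nitrogen, butyl in place of isopropyl on a sulfur gives a 3.8-fold lower number from compound 2 to compound 4 (0.57 log units; beyond the scatter), so a change at the sulfur can also go beyond the scatter, unlike the different change at the sulfur in a 1.1-fold lower number from compound 1 to compound 3 (0.04 log units; within the scatter), made with butyl on the nitrogen. No available evidence accounts for either step.

On these data alone, whether a longer chain such as octyl on that nitrogen continues the trend, or an amine on the hexyl chain retains the step, stays open. Also open, as far as these compounds go, is whether the butyl to hexyl step holds with ethyl or isopropyl on the sulfur.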